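Carboxy on the ethyl chain of compound 2

A few compounds are considered here, and "the series" means these few. Any claim that something is new, unique, unknown or untested is made for them only; others in the source may bear on it.

Measured in a functional assay on NCI-H460 cells (Homo sapiens) for inhibition, with a stated time of 72 h; a lower number here means a stronger inhibitor, a higher number a weaker inhibitor:
- compound 1 `COc1cc(C(=O)c2cccc3cc[nH]c23)cc(OC)c1OC` gives 295 nM
- compound 2 `CCn1ccc2cc(C(=O)c3cc(OC)c(OC)c(OC)c3)ccc21` gives 38 nM

Compound 2 has the lower of the two numbers, and its gap to compound 1 lies beyond the scatter. Compound 3 `COc1cc(C(=O)c2ccc3c(ccn3CCC(=O)O)c2)cc(OC)c1OC` departs from compound 2 by carboxy in place of hydrogen on a saturated chain carbon, two bonds along the chain from an aromatic nitrogen. Going by the values given here, no measured pair shows this change, so the expectation is a judgement only. A weaker result in this assay is expected, beyond the scatter, as an estimated 7.9-fold higher number from compound 2 to compound 3 (0.90 log units; beyond the scatter). The value expected for compound 3 is 300 nM, within a range of 60 nM to 2500 nM.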

Compound 3, half-maximal inhibitory concentration: > 10000 nM
Compound 3 was reported as a limit (the forecaster's own chance of this, stated with the estimate: 10%); middle value at least 33-fold (1.52 log units) from the limit.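

On the ethyl chain, carboxy in place of hydrogen gives an at least 260-fold higher number from compound 2 to compound 3 (2.42 log units; beyond the scatter) in this assay. Going by these compounds alone, this is the first step that differs in one place, and it shows that the ethyl chain of compound 2 does not accept every change at this position. Compound 3 stands as a limit, not a number: the limit of > 10000 nM in this assay, at which 1 of the 3 values shown sits.

From the compounds shown here alone, whether the loss follows the carboxy group alone stays open. A methyl ester, a primary amide or an amine at the chain end, or a longer chain carrying the carboxy group, would bear on that.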